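The source may hold more compounds than are shown below. What is called first, only, known or untested is meant among the compounds shown, and "the series" means these compounds.

Measured compounds:
compound 1, `CCC1=C(O)c2c(oc(-c3ccc(OC)cc3)cc2=O)C(CC)(CC)C1=O`, with 0.68 uM
compound 2, `CCC1=C(O)c2c(oc(-c3ccc(F)cc3)cc2=O)C(CC)(CC)C1=O`, with 1.85 uM
compound 3, `CCC1=C(O)c2c(oc(-c3ccc(OC)c(OC)c3)cc2=O)C(CC)(CC)C1=O`, with 1 uM

These three compounds were tested in a functional assay on KBVIN cells (Homo sapiens) for antiproliferative activity, read by sulforhodamine B assay, with a stated time of 3 days; on this read-out lower numbers stand for an effect already at smaller amounts and higher numbers for an effect only at larger amounts of compound. Compound 2 differs from compound 1 by fluoro in place of methoxy on an aromatic carbon, and that change brought a 2.7-fold higher number from compound 1 to compound 2 (0.43 log units; beyond the scatter). Compound 3 differs from compound 1 by methoxy in place of hydrogen on an aromatic carbon, a step of a 1.5-fold higher number from compound 1 to compound 3 (0.17 log units; within the scatter). Compound 4, `CCC1=C(O)c2c(oc(-c3ccc(OC)c(F)c3)cc2=O)C(CC)(CC)C1=O`, has not yet been measured; it differs from compound 3 by fluoro in place of methoxy on an aromatic carbon. For the measured compounds named here, this is the same kind of change as the one from compound 1 to compound 2, but the place is not the same: in compound 1 the exchanged group sits para to a large group, while in compound 3 it sits ortho to a methoxy group and meta to a large group. For compound 4 in this assay a step of about a 2.2-fold higher number from compound 3 to compound 4 (0.34 log units; beyond the scatter) is expected, close to the earlier one, because the same kind of change gave a 2.7-fold higher number from compound 1 to compound 2 (0.43 log units; beyond the scatter). The estimate for compound 4 is therefore 2.2 uM, likely between 1 uM and 4.8 uM.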

Compound 4, concentration for half-maximal effect: 0.1 uM
Compound 4: the middle estimate sits 22-fold (1.34 log units) above what was measured; the measured number lies below the stated range.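

Exchanging methoxy for fluoro does not carry over from one core to the other in this series, and the two steps even run in opposite directions: the same change on two cores in this assay, a 2.7-fold higher number (0.43 log units; beyond the scatter) from compound 1 to compound 2 and a 10-fold lower number (1.00 log units; beyond the scatter) from compound 3 to compound 4, 27-fold (1.43 log units) apart, beyond the scatter of two such steps Compound 4 also stands apart from each of the other compounds, with a 10-fold lower number from compound 3 to compound 4 (1.00 log units; beyond the scatter), a 19-fold lower number from compound 2 to compound 4 (1.27 log units; beyond the scatter) and a 6.8-fold lower number from compound 1 to compound 4 (0.83 log units; beyond the scatter), so the lower number belongs to this particular combination of fluoro and methoxy on the ring, not to fluoro alone. For the compounds shown here, this shows that the outcome of the exchange changes with what else sits on the ring, but with only two pairs it does not show why, nor what the same exchange would do on any further core.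

On these data alone, it remains open whether another group in the place of the fluoro in compound 4, such as chloro, hydroxy or an amine, would give a similarly low number. Also open, as far as these compounds go, is how a longer chain, such as ethoxy, in place of the methoxy of compound 4 would behave.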